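A few compounds are considered here, and "the series" means these few. Any claim that something is new, unique, unknown or untested is made for them only; others in the source may bear on it.

Measured compounds:
Compound 1 `N#Cc1ccn2c(-c3ccccc3)c(-c3ccccc3)c(C(O)C3CCCCC3)c2c1` — in an assay for inhibition of Polyunsaturated fatty acid lipoxygenase ALOX15 (Oryctolagus cuniculus) (on this read-out lower numbers stand for stronger inhibition and higher numbers for weaker inhibition), compound 1 gives "not determined" (no result reported).
Compound 2 `COc1cccc(C(=O)Oc2c(-c3ccccc3)c(-c3ccccc3)n3ccc(C#N)cc23)c1` — in this assay compound 2 gives "not determined" (no result reported).
Compound 3 `Cc1ccc(S(=O)(=O)Oc2c(-c3ccccc3)c(-c3ccccc3)n3ccc(C#N)cc23)cc1` — in this assay compound 3 gives 25000 nM.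

Within the data shown here, compound 3 holds the only number in this assay; compounds 1 and 2 have no result at all, so compound 3 cannot be compared with anything and stands simply as a weak inhibitor on its own. Compound 4 `N#Cc1ccn2c(-c3ccccc3)c(-c3ccccc3)c(C=O)c2c1` is the next structure, and it differs from compound 3 in one place: formyl in place of ((4-methylphenyl)sulfonyl)oxy on an aromatic carbon. Among the measured compounds shown here, the leaving group is large and the entering formyl is small, yet there is no pair of measured compounds here that would show what such a change does in this assay. Without any measured step to rest on, the most defensible expectation for the step of a 1.2-fold higher number from compound 3 to compound 4 (0.08 log units; within the scatter) is one of no change beyond the scatter, in either direction. Compound 4 is therefore estimated at 30000 nM, with a range from 6000 nM to 150000 nM to reflect that uncertainty.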

Compound 4, half-maximal inhibitory concentration: 61000 nM
Beside the measured number, compound 4's estimate is 2.0-fold (0.31 log units) below it; the measured number falls inside the stated range.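

In this assay, among these compounds, replacing the ((4-methylphenyl)sulfonyl)oxy group on this aromatic carbon with formyl gives a 2.4-fold higher number from compound 3 to compound 4 (0.39 log units; beyond the scatter), the first measured step at this position, and it is modest but beyond the usual scatter. Going from a group of 11 heavy atoms with a six-membered aromatic ring to one of 2 heavy atoms with no ring therefore weakens inhibition, yet it leaves a measurable number, so that ring is not needed for this weak level of inhibition. Nothing available explains why the number rises.

Steps to compound 1 and compound 2 cannot be read, as neither has a number. On these data alone, whether an amine, a carboxylic acid or a longer chain on this carbon would give stronger or weaker inhibition remains open.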